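This account rests on a few compounds, and the source may have more. Where it says the series, first, only, none or still open, it means among the compounds named here.

Measured so far:
compound 1, `O=C(O)C1CC1c1ccc(C#Cc2cc(Cl)nc(Cl)c2)cc1`: 96%
compound 2, `O=C(O)CCc1ccc(C#Cc2ccnc(F)c2)cc1`: 98%

Of the compounds shown here, two have been measured in an in vitro functional assay on 1321-N1 cells for agonist activity at Free fatty acid receptor 1 (Homo sapiens), read by fluorescence, spectrophotometry and calcium flux; on this read-out higher numbers stand for larger maximal responses and lower numbers for smaller maximal responses. Compound 1, `O=C(O)C1CC1c1ccc(C#Cc2cc(Cl)nc(Cl)c2)cc1`, gives 96% in this assay, and compound 2, `O=C(O)CCc1ccc(C#Cc2ccnc(F)c2)cc1`, gives 98%. The two numbers lie within the usual scatter of each other, so nothing separates compound 2 from compound 1 on this read-out; both reach a maximal response close to that of the reference.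

The next compound, compound 3, `O=C(O)CCc1ccc(C#Cc2ccnc(-c3ccccc3)c2)cc1`, differs from compound 2 in one place: phenyl in place of fluoro on an aromatic carbon. Within the data shown here, no step between measured compounds is available that would show what such a change does in this assay, and compound 1 differs from compound 2 in several places at once, so it offers no guide either. Since both measured compounds sit near the top of the scale, there is little room upward; a step of no size beyond the scatter is expected, with any deviation more likely downward than upward. The step from a number 8 percentage points lower from compound 2 to compound 3 (within the scatter) is therefore estimated to be small. Compound 3 is expected to give about 90% in this assay, within a range from 65% to 105%.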

Compound 3, largest response reached (reported as efficacy), in percent of the reference or control that the assay uses: 97%
Estimate against measurement, compound 3: 7 percentage points below; the measured number falls inside the stated range.
By their numbers in this assay, from the lowest: compounds 1, 3 and 2 (each within the scatter of the next).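

In this assay, phenyl in place of fluoro on an aromatic carbon, next to the ring nitrogen, gives a number 1 percentage points lower from compound 2 to compound 3 (within the scatter) and so leaves no difference that can be told from the scatter. Until now this place had been seen carrying only fluoro, a group of 1 heavy atom, whereas compound 3 shows that a phenyl group of 6 heavy atoms, with its one six-membered aromatic ring of carbon only, can stand there while the maximal response remains close to that of the reference. Nothing available explains why these two groups give such similar responses.

This single step rests on one pair and on the largest response alone, so it does not show how far the finding extends to other groups at this place, such as an amine, a methoxy group or a saturated ring like morpholine. Also open, on these data alone, is whether phenyl would behave the same way with a longer chain carrying the carboxylic acid, or whether substituents on the phenyl ring itself would bring the response beyond the scatter.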